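This account rests on a few compounds, and the source may have more. Where it says the series, first, only, none or still open, it means among the compounds named here.

Within the data shown here, in a functional assay on MIA PaCa-2 cells (Homo sapiens) for antiproliferative activity (a higher number here means that more compound is needed for the effect, a lower number that less compound is needed), compound 1 `Cc1cc2c(C(N)=O)cccc2n1-c1nc2c(c(NCc3ccccc3)n1)COCC2` gives 146 nM, the lowest of the three numbers measured so far and beyond the scatter from both others. Compound 2 `C#CCCNC(=O)c1cccc2c1cc(C)n2-c1nc2c(c(NCc3ccccc3)n1)CCCC2` gives 1410 nM, and compound 3 `C=CC#CC(=O)Nc1cccc2c1cc(C)n2-c1nc2c(c(NCc3ccccc3)n1)CCCC2` gives 892 nM. The change leading to compound 4 `CC#CC(=O)Nc1cccc2c1cc(C)n2-c1nc2c(c(NCc3ccccc3)n1)COCC2` is ((prop-1-yn-1-yl)carbonyl)amino in place of carbamoyl on an aromatic carbon. Among the measured compounds shown here, no measured step makes this exact change. The one that bears on it is a 1.6-fold lower number from compound 2 to compound 3 (0.20 log units; within the scatter), an exchange of one group without a ring for another on an aromatic carbon, so swapping such groups moved the number little in that pair. Both of these compounds carry a larger group than carbamoyl, and compound 3, the nearer of the two, still stands at 892 nM. The new group in compound 4 is also larger than carbamoyl, so a rise beyond the scatter is expected, though the data cannot settle its size. The expected change in this assay is a 3.8-fold higher number from compound 1 to compound 4 (0.58 log units; beyond the scatter). Compound 4 is estimated at 550 nM, with an expected range of 180 nM to 1600 nM.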

Compound 4, half-maximal effective concentration: 600 nM
Compound 4: the middle estimate sits 1.1-fold (0.04 log units) below what was measured; low and high end bracket the measured number.
By their numbers in this assay, from the lowest: compound 1; then compounds 4, 3 and 2 (each within the scatter of the next, the first and the last beyond it).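

In this assay, ((prop-1-yn-1-yl)carbonyl)amino in place of carbamoyl on this aromatic carbon gives a 4.1-fold higher number from compound 1 to compound 4 (0.61 log units; beyond the scatter) and so provides a direct reading of a change at this position on the core of compound 1. Unlike the earlier exchange between two groups of equal heavy-atom count, this change raises the heavy atoms of the group from 3 to 6, while the hydrogen-bond donor and acceptor counts stay the same, and the number still moves beyond the scatter. Nothing measured here accounts for this rise.

Among these compounds, the single step cannot separate the effect of the longer group from that of the triple bond or the turned amide link. On these data alone, whether acetylamino, a simple amine or a carboxylic acid on this carbon would stay closer to compound 1 also remains open.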